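A butyl group added to the aryl ring of compound 2

The source may report more compounds than this note shows. Statements on the series, on what has been measured and on what is new or still open speak of the compounds shown alone.

Compound 2 `Oc1nc2nonc2nc1Nc1ccccc1F` is second highest of the three numbers available in an assay on mitochondria from L6 cells (Rattus norvegicus) for activation, with a stated time of 90 min (on this read-out higher numbers stand for an effect only at larger amounts of compound and lower numbers for an effect already at smaller amounts), where compound 2 gives 12500 nM. Its nearest neighbour is compound 3 `Oc1nc2nonc2nc1Nc1ccccc1`, for which compound 3 gives 66700 nM, a step of a 5.3-fold higher number from compound 2 to compound 3 (0.73 log units; beyond the scatter). Furthest away is compound 1 `Fc1cccc(Nc2nc3nonc3nc2Nc2ccccc2F)c1`; in this assay compound 1 gives 190 nM, and the step is a 66-fold higher number from compound 1 to compound 2 (1.82 log units; beyond the scatter).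

Compound 4 `CCCCc1ccc(Nc2nc3nonc3nc2O)c(F)c1` differs from compound 2 in one place: butyl in place of hydrogen on an aromatic carbon. For the measured compounds named here, the two measured steps, one large and one modest, concern the hydroxy replacing the (3-fluorophenyl)amino group and the fluoro replacing hydrogen; neither tests a butyl entering on an aromatic carbon of a six-membered aromatic ring of carbon only, so there is no direct precedent. The step of a 5.3-fold higher number from compound 2 to compound 3 (0.73 log units; beyond the scatter) shows that a change on this ring can move the number modestly, while the step of a 66-fold higher number from compound 1 to compound 2 (1.82 log units; beyond the scatter) shows what a large change looks like.

For compound 4 the expected step is therefore a 1.6-fold lower number from compound 2 to compound 4 (0.19 log units; within the scatter), not beyond the scatter, with the direction uncertain. Compound 4 is estimated at 8000 nM in this assay, within a range from 2000 nM to 30000 nM.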

Compound 4, half-maximal effective concentration: 1100 nM
Compound 4: middle estimate off by 7.3-fold (0.86 log units), on the high side; measured number below the stated range.
By their numbers in this assay, from the lowest: compound 1; then compound 4; then compound 2; then compound 3.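

In this assay, butyl in place of hydrogen on an aromatic carbon, meta to a fluoro group and para to a large group, gives an 11-fold lower number from compound 2 to compound 4 (1.06 log units; beyond the scatter). For the compounds shown here, the earlier compounds showed only a modest move on this ring, a 5.3-fold higher number from compound 2 to compound 3 (0.73 log units; beyond the scatter), so this is the first sign that a large change in the number can come from this ring, and from a group that adds a chain of carbon alone. No measurement offered here accounts for the step.

Still open, on these data alone, is whether the change belongs to butyl as such, or whether methyl, a longer chain such as hexyl, an amine or a carboxylic acid at this place would move the number as far. Also open, as far as these compounds go, is whether butyl would give a similar step on compound 3, which lacks the fluoro group, or on compound 1.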